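The source may hold more compounds than are shown below. What is called first, only, known or untested is meant among the compounds shown, and "the series" means these compounds.

Among the compounds with values here, compound 2 `CCCCCOc1ccccc1C1CC(=O)c2ccccc2O1` stands lowest of the two compounds measured so far in a functional assay on J774.A1 cells (Mus musculus) for inhibition, read by immunoassay, with a stated time of 12 h, tested at 30 uM; on this read-out lower numbers stand for less inhibition and higher numbers for more inhibition at the one concentration tested (going by the name of the read-out); compound 2 gives 40.1%. Its nearest neighbour is compound 1 `CC(C)c1ccc(COc2ccccc2C2CC(=O)c3ccccc3O2)cc1`, which in this assay gives 91.7%. Within the data shown here, the one step so far, butyl in place of 4-isopropylphenyl on a saturated chain carbon bound to an oxygen on an aromatic ring, is a number 51.6 percentage points lower from compound 1 to compound 2 (beyond the scatter), a large loss well beyond the scatter.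

Compound 3 `COCOc1ccccc1C1CC(=O)c2ccccc2O1` is not yet measured. It differs from compound 2 as follows: methoxy in place of butyl on a saturated chain carbon bound to an oxygen on an aromatic ring.

The step from compound 1 to compound 2 bears on this only loosely: it showed that trimming the group on the saturated chain carbon bound to an oxygen on an aromatic ring cost a great deal, and compound 3 trims further, from butyl to methoxy. Among the measured compounds shown here, no measured step covers that exact change, so the direction is uncertain; a further drop or no change beyond the scatter both seem possible. Compound 3 is therefore expected to give about 30% in this assay, within a range of 5% to 60%. That estimate means a step of a number 10.1 percentage points lower from compound 2 to compound 3 (beyond the scatter), expected to be modest and downward.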

Compound 3, a percentage reported as inhibition, at one concentration (the size of the read-out at that concentration, not a potency): 33.3%
Beside the measured number, compound 3's estimate is 3.3 percentage points below it; low and high end bracket the measured number.
By their numbers in this assay, from the lowest: compounds 3 and 2 (each within the scatter of the next); then compound 1.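

In this assay, methoxy in place of butyl on a saturated chain carbon bound to an oxygen on an aromatic ring gives a number 6.8 percentage points lower from compound 2 to compound 3 (within the scatter), so this exchange, which replaces an all-carbon group with one that holds an oxygen and a hydrogen-bond acceptor, leaves the two compounds indistinguishable on this read-out. Methoxy in place of 4-isopropylphenyl at the same place gives a number 58.4 percentage points lower from compound 1 to compound 3 (beyond the scatter), a large step of the same kind as a number 51.6 percentage points lower from compound 1 to compound 2 (beyond the scatter), so among these three compounds the large separation falls between compound 1 and the other two, not between butyl and methoxy. Nothing available explains why 4-isopropylphenyl stands apart from both smaller groups here.

These compounds leave open whether a plain phenyl, a cyclohexyl or a longer chain such as octyl at this place would give numbers near those of compound 1 or those of compound 2 and compound 3, and so whether the ring, the isopropyl or the size of the group matters. They also leave open how the three compounds would compare at other concentrations, since a single-concentration read-out gives no potency.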